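The compounds below may be only part of what the source reports. "The series", "measured", "known", "first", "only" and "open" are said of these compounds alone.

Compound 1 `CCC(C)C(NC(=O)c1ccc(C(CC)(CC)c2ccc(OCCC(O)(CC)CC)c(C)c2)n1CC)C(=O)O`: 20000 nM
Compound 2 `CCn1c(C(=O)NC(CC(=O)O)C(=O)OC)ccc1C(CC)(CC)c1ccc(OCCC(O)(CC)CC)c(C)c1`: 25200 nM

Among the measured compounds shown here, in a functional assay on Caco-2 cells (Homo sapiens) for antiproliferative activity, read by MTT assay, with a stated time of 48 h (a lower number here means a stronger inhibitor, a higher number a weaker inhibitor), compound 2 stands level with compound 1, the only other compound measured, and the step is a 1.3-fold higher number from compound 1 to compound 2 (0.10 log units; within the scatter). Compound 3 `CCn1c(C(=O)NC(C)C(=O)O)ccc1C(CC)(CC)c1ccc(OCCC(O)(CC)CC)c(C)c1` carries 1-carboxyethyl on an amide-type nitrogen: a group of 5 heavy atoms (3 carbon, 2 oxygen; no ring) in place of a group of 9 heavy atoms (5 carbon, 4 oxygen; no ring), on an amide-type nitrogen. That single measured step bears on this change, since it exchanged one group for another at the same place without leaving the scatter. No step beyond the scatter is therefore expected in this assay. The estimated step is a 1.1-fold lower number from compound 2 to compound 3 (0.06 log units; within the scatter). For compound 3 the expected value is 22000 nM, with an estimated range of 10000 nM to 46000 nM.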

Compound 3, half-maximal inhibitory concentration: 46500 nM
Beside the measured number, compound 3's estimate is 2.1-fold (0.33 log units) below it, and the stated range ends below it.
By their numbers in this assay, from the lowest: compounds 1, 2 and 3 (each within the scatter of the next, the first and the last beyond it).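

In this assay, among the compounds shown here, the step of a 2.3-fold higher number from compound 1 to compound 3 (0.37 log units; beyond the scatter) comes with methyl in place of sec-butyl on a saturated chain carbon bound to an amide-type nitrogen and a carbonyl carbon; it is the first step at this position beyond the scatter, though a modest one. The step of a 1.8-fold higher number from compound 2 to compound 3 (0.27 log units; within the scatter) stays within the scatter, so 1-carboxyethyl is not set apart from the group it replaces in compound 2. Nothing available accounts for either step. The compounds shown leave open how an amine or a longer unbranched chain on that saturated carbon would read in this assay.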